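Isopropyl to ethyl on a sulfur

The source may hold more compounds than are shown below. What is called first, only, known or untested is meant among the compounds shown, and "the series" means these compounds.

Measured so far in a functional assay on HeLa cells (Homo sapiens) for antiproliferative activity, read by resazurin assay; a lower number here means a stronger inhibitor, a higher number a weaker inhibitor
Compound 1 `O=C(CSC(=S)Sc1ccccc1)c1ccc(Cl)c(Cl)c1` gives 20000 nM
Compound 2 `CC(C)SC(=S)SCC(=O)c1ccc(Cl)c(Cl)c1` gives 25100 nM

Compound 2 at 25100 nM lies within the scatter of compound 1 at 20000 nM and so neither can be ranked above the other. Compound 3 `CCSC(=S)SCC(=O)c1ccc(Cl)c(Cl)c1` has not yet been measured. It differs from compound 2 by hydrogen in place of methyl on a saturated chain carbon bound to a saturated chain carbon and a sulfur and this reads as isopropyl to ethyl, with hydrogen in place of methyl on a saturated chain carbon bound to a saturated chain carbon and a sulfur. Within the data shown here, the one measured step that bears on this is a 1.3-fold higher number from compound 1 to compound 2 (0.10 log units; within the scatter) for isopropyl in place of phenyl on a sulfur, and it stays within the scatter. No step beyond the scatter is therefore expected in this assay and no direction can be given. The estimated step is a 1.1-fold lower number from compound 2 to compound 3 (0.06 log units; within the scatter) and it stays within the scatter. For compound 3 the expected value is 22000 nM with an estimated range from 12000 nM to 40000 nM as the likely span.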

Compound 3, half-maximal inhibitory concentration: 7940 nM
Compound 3: middle estimate off by 2.8-fold (0.44 log units), on the high side; measured number below the stated range.
By their numbers in this assay, from the lowest: compound 3; then compounds 1 and 2 (each within the scatter of the next).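

In this assay, the group on this sulfur now makes a measurable difference, which the phenyl and isopropyl pair of compounds 1 and 2 did not show. Losing one methyl, as isopropyl becomes ethyl, gives a 3.2-fold lower number from compound 2 to compound 3 (0.50 log units; beyond the scatter) and is thus enough for a step beyond the scatter. Ethyl in place of phenyl gives a 2.5-fold lower number from compound 1 to compound 3 (0.40 log units; beyond the scatter) as well, so ethyl stands apart from both other groups, though no available evidence explains this difference.

The compounds shown do not reveal whether methyl or a longer straight chain such as n-propyl on this sulfur would fall nearer compound 3 or nearer compounds 1 and 2. They also leave open how a chain ending in an amine or a carboxylic acid would behave here.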